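Swapping a para substituent on the benzylamine arm

This account rests on a few compounds, and the source may have more. Where it says the series, first, only, none or still open, it means among the compounds named here.

Compound 2 `COc1ccc(CNCc2c(OC)cc(Oc3cccc(Nc4ccccc4)c3)cc2OC)cc1` carries a (4-methoxybenzyl)amino group on its shared core. In a functional assay on HT-29 cells (Homo sapiens) for inhibition, read by MTT assay, with a stated time of 72 h (on this read-out lower numbers stand for stronger inhibition and higher numbers for weaker inhibition), compound 2 gives 1890 nM. For the measured compounds named here, its only measured relative is compound 1 `COc1cc(Oc2cccc(Nc3ccccc3)c2)cc(OC)c1CNCc1ccc(Br)cc1`, which differs by bearing bromo where compound 2 bears methoxy; in this assay compound 1 gives 3060 nM. Going by the values given here, the one measured step, a 1.6-fold lower number from compound 1 to compound 2 (0.21 log units; within the scatter), shows that exchanging these two groups on the aromatic carbon changes the number by no more than the usual scatter, so the two compounds cannot be ranked against each other.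

Compound 3 `COc1cc(Oc2cccc(Nc3ccccc3)c2)cc(OC)c1CNCc1ccc(F)cc1` makes a change at the same place: fluoro in place of methoxy on an aromatic carbon. Among the compounds with values here, only the step from compound 1 to compound 2 speaks to a change at this position, and it was small, so a further exchange there is expected to move the number little, if at all, in this assay. The step of a 1.3-fold higher number from compound 2 to compound 3 (0.12 log units; within the scatter) is the expected outcome. Compound 3 is therefore estimated at 2500 nM, with a range from 1200 nM to 5200 nM.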

Compound 3, half-maximal inhibitory concentration: 2750 nM
Compound 3: middle estimate off by 1.1-fold (0.04 log units), on the low side; the range from low to high includes it.
By their numbers in this assay, from the lowest: compounds 2, 3 and 1 (each within the scatter of the next).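

In this assay, two new steps can be read: a 1.5-fold higher number from compound 2 to compound 3 (0.16 log units; within the scatter), and a 1.1-fold lower number from compound 1 to compound 3 (0.05 log units; within the scatter). Both lie within the usual scatter, so fluoro cannot be ranked against either methoxy or bromo. Where a single pair stood before, there are now three pairs, and none of them separates its two compounds, so for these three groups the aromatic carbon shows no difference that rises above the scatter. Nothing measured here offers an explanation for why the three compounds read alike.

As far as these compounds go, all three groups are small single substituents, so it remains open whether an amine, a carboxylic acid or a longer chain such as butoxy on the same carbon would stay within the scatter or go beyond it. The three compounds also differ at this one place only, which leaves open what a change elsewhere on the shared core would do to the number.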